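Methyl Substitution and Cytotoxicity in MT4 Cells

The source may report more compounds than this note shows. Statements on the series, on what has been measured and on what is new or still open speak of the compounds shown alone.

Measured compounds:
compound 1, `Cc1cc(C#N)ccc1-c1ccc(Oc2ccnc(Nc3ccc(C#N)cc3)n2)c(F)c1`: > 296000 nM
compound 2, `N#Cc1ccc(Nc2nccc(Oc3ccc(-c4ccc(C#N)cc4)c(Cl)c3)n2)cc1`: 31100 nM
compound 3, `N#Cc1ccc(Nc2nccc(Oc3ccc(-c4ccc(C#N)cc4)cc3F)n2)cc1`: > 307000 nM

In a functional assay on MT4 cells (Homo sapiens) for cytotoxicity, read by MTT assay, with a stated time of 5 days (on this read-out higher numbers stand for lower toxicity in this test and lower numbers for higher toxicity in this test), compound 1 gives only a limit, > 296000 nM. Compound 3 likewise gives only a limit in this assay, > 307000 nM. For the measured compounds named here, compound 2 is the one compound with a number in this assay, 31100 nM. The difference between the core of compound 2 and that of compound 3 is not broken down here.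

Compounds 3 and 1 differ by methyl in place of hydrogen on an aromatic carbon. With both values at limits, a step that the two limits leave unreadable from compound 3 to compound 1; what is known of the pair is the limit of > 307000 nM in this assay, at which 1 of the 3 values shown sits, and (the limit of > 296000 nM in this assay, at which 1 of the 3 values shown sits). Compound 4, `Cc1cc(-c2ccc(C#N)cc2)c(Cl)cc1Oc1ccnc(Nc2ccc(C#N)cc2)n1`, stands to compound 2 as compound 1 stands to compound 3: methyl in place of hydrogen on an aromatic carbon. This is the same kind of change, not the same one, for in compound 4 the methyl enters meta to a 4-cyanophenyl group and para to a chloro group, whereas in compound 1 it enters meta to a cyano group.

Going by the values given here, no measured step tells the size of this change. For compound 4 the expected step in this assay is a 1.0-fold lower number from compound 2 to compound 4 (0.02 log units; within the scatter). Compound 4 is thus expected at about 30000 nM, between 10000 nM and 100000 nM.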

Compound 4, half-maximal cytotoxic concentration: > 285000 nM
Compound 4: only a limit was reported (the forecaster's own chance of this, stated with the estimate: 15%); at least 9.5-fold (0.97 log units) between middle value and limit.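

From the compounds shown here alone, on the core of compound 2, methyl in place of hydrogen on an aromatic carbon gives an at least 9.1-fold higher number from compound 2 to compound 4 (0.96 log units; beyond the scatter) in this assay, which points to lower toxicity in this test; compound 4 stands at a limit, so the size printed is only a floor and the full size of the step stays unknown. This shows the change on one core only. The matching step from compound 3 to compound 1 has a limit at both ends and cannot be read. The compounds shown neither confirm nor contradict that the change carries from one core to the other, and the methyl does not enter at the same place in compound 1 and compound 4. Nothing measured here gives a reason for the step on the core of compound 2.

The compounds shown leave open how far compound 4 really lies from compound 2. They also leave open whether an ethyl or a methoxy group entering at the place of this methyl would go the same way in this assay on either core.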